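The source may report more compounds than this note shows. Statements on the series, on what has been measured and on what is new or still open speak of the compounds shown alone.

Of the compounds shown here, three that share one amide core have been measured in a functional assay on A-375 cells (Homo sapiens) for antiproliferative activity; on this read-out higher numbers stand for weaker inhibition and lower numbers for stronger inhibition. Compound 1 `O=C(Nc1ccc(-c2cscn2)cc1)C1CCN(Cc2ccc(F)c(F)c2)CC1` reaches only the limit of this assay, > 20000 nM. Compound 2 `O=C(Nc1ccc2scnc2c1)C1CCCN(Cc2ccc(F)c(F)c2)C1` likewise gives only a limit in this assay, > 20000 nM. Among the measured compounds shown here, compound 3 `O=C(Nc1ccc(-c2cscn2)cc1)C1CCCN(Cc2ccccc2F)C1` is the single member of the set with a number rather than a limit, giving 4000 nM in this assay. The other two values sit at the limit of > 20000 nM in this assay, at which 2 of the 3 values shown sit. For the measured compounds named here, compound 3 therefore stands alone as the only measured number, and no step between measured compounds can be counted.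

Compound 4 `O=C(Nc1ccc(-c2cscn2)cc1)C1CCCN(Cc2ccc3cn[nH]c3c2)C1` has not yet been measured in this assay. It differs from compound 3 in one place: 1H-indazol-6-yl in place of 2-fluorophenyl on a saturated chain carbon bound to an amine nitrogen in a ring. The group that enters carries one hydrogen-bond donor and one hydrogen-bond acceptor, where the group that leaves carries none. Going by the values given here, with no measured step to guide the direction, the expectation rests on compound 3 alone. Compound 4 is expected to give 2000 nM in this assay, within a range from 400 nM to 10000 nM. This estimate means a step of a 2.0-fold lower number from compound 3 to compound 4 (0.30 log units; within the scatter) that is expected to be modest, toward stronger inhibition, and not far beyond the usual scatter.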

Compound 4, half-maximal inhibitory concentration: > 20000 nM
Compound 4 was reported as a limit (the forecaster's own chance of this, stated with the estimate: 15%); middle value at least 10-fold (1.00 log units) from the limit.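

Compound 4 gives only a limit in this assay, > 20000 nM. Among the compounds shown here, the earlier compounds offered no pair differing in one place, so this is the first direct reading of a change on a saturated chain carbon bound to an amine nitrogen in a ring: 1H-indazol-6-yl in place of 2-fluorophenyl gives an at least 5.0-fold higher number from compound 3 to compound 4 (0.69 log units; beyond the scatter), which shows that the measurable value of compound 3 does not survive this exchange and that the group at this position matters in this assay. Compound 3 remains the only compound with a number, so the set gives no second value against which to size the change, and its readings otherwise stand here: the limit of > 20000 nM in this assay, at which 3 of the 4 values shown sit.

Whether the added ring, the ring nitrogens or the hydrogen-bond donor accounts for this step cannot be separated from one pair. Going by these compounds, a plain phenyl, a pyridinyl or a naphthyl group at this position would be needed to tell these apart, and it stays open whether the fluorine of the 2-fluorophenyl group contributes to the value of compound 3.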